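The compounds below may be only part of what the source reports. "The series", "measured", "known", "first", "only" and "open" are said of these compounds alone.

Compound 2, with the structure `Cc1ccc2ccn(CCN3CCCN(C)CC3)c2c1`, is one of two measured compounds sharing a common core. In an assay on HEK293 cells for binding affinity to 5-hydroxytryptamine receptor 7 (Homo sapiens), read by radioligand binding (a lower number here means a stronger inhibitor, a higher number a weaker inhibitor), compound 2 gives 125 nM, the higher of the two numbers recorded, though only just: compound 1, with the structure `C=Cc1ccc2ccn(CCN3CCCN(C)CC3)c2c1`, gives 109 nM in this assay, and the gap between the two lies within the usual scatter. Among the compounds with values here, the only measured step is a 1.1-fold higher number from compound 1 to compound 2 (0.06 log units; within the scatter), so swapping a vinyl group for a methyl group at that position left the binding essentially unchanged.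

Compound 3, with the structure `C=C(C)c1ccc2ccn(CCN3CCCN(C)CC3)c2c1`, has not yet been measured. It differs from compound 2 by 1-methylethenyl in place of methyl on an aromatic carbon. Within the data shown here, this change is closely related to the one measured step, since it again exchanges a small saturated group for a small unsaturated one at the same position, only in the opposite direction and with one extra carbon. Because that step, a 1.1-fold higher number from compound 1 to compound 2 (0.06 log units; within the scatter), fell within the scatter, no shift beyond the scatter is expected here either. The estimated step is a 1.1-fold lower number from compound 2 to compound 3 (0.04 log units; within the scatter), and compound 3 is expected to give about 115 nM in this assay, with a likely range from 50 nM to 270 nM.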

Compound 3, inhibition constant: 70 nM
Compound 3: middle estimate off by 1.6-fold (0.22 log units), on the high side, and the stated range covers the measured number.
By their numbers in this assay, from the lowest: compounds 3, 1 and 2 (each within the scatter of the next).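

In this assay, putting 1-methylethenyl in place of methyl on this aromatic carbon gives a 1.8-fold lower number from compound 2 to compound 3 (0.25 log units; within the scatter) and stays within the scatter, so a group of 3 heavy atoms is accepted here about as well as a group of 1 heavy atom. Adding a methyl to the double-bonded chain carbon bound to the aromatic carbon gives a 1.6-fold lower number from compound 1 to compound 3 (0.19 log units; within the scatter) and also stays within the scatter, so this extra branch on the vinyl group brings no clear gain or loss in binding. Methyl, vinyl and 1-methylethenyl therefore cannot be told apart at this position in this assay, and nothing available offers an explanation for the small differences between them.

All three groups at this position are built from carbon and hydrogen only, so what an amine, a carboxylic acid, a methoxy group or a longer chain would do there remains an open question. Also open, from the compounds shown here alone, is whether a group on another aromatic carbon of the shared core would be accepted as readily as these three are.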